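From 6-fluoropyridin-3-yl to pyridin-4-yl in compound 4

The compounds below may be only part of what the source reports. "The series", "measured", "known", "first", "only" and "open" are said of these compounds alone.

Compound 1 `COc1ccc(CN2CCN(c3ccc(C4CC(c5ccc([N+](=O)[O-])o5)=NO4)cc3)CC2)cn1` gives > 50000 nM as a limit.
Compound 2 `O=[N+]([O-])c1ccc(C2=NOC(c3ccc(N4CCN(Cc5ccc(F)nc5)CC4)cc3)C2)o1` gives > 50000 nM as a limit.
Compound 3 `O=[N+]([O-])c1ccc(C2=NOC(c3ccc(-c4ccncc4)cc3)C2)o1` gives > 50000 nM as a limit.

These readings come from an ADME assay on HeLa cells (Homo sapiens) for cytotoxicity, read by MTT assay, with a stated time of 96 h (a higher number here means a weaker inhibitor, a lower number a stronger inhibitor), and none of them is a number. Compound 2 stands only at its limit of > 50000 nM in that test. What the three compounds share is the limit of > 50000 nM in this assay, at which 3 of the 3 values shown sit, and the series offers no measured number to work from.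

Compound 4 `O=[N+]([O-])c1ccc(C2=NOC(c3ccc(N4CCN(Cc5ccncc5)CC4)cc3)C2)o1` is the one still to be read. It differs from compound 2 as follows: pyridin-4-yl in place of 6-fluoropyridin-3-yl on a saturated chain carbon bound to an amine nitrogen in a ring with pyridin-4-yl in place of 6-fluoropyridin-3-yl on a saturated chain carbon bound to an amine nitrogen in a ring. For the measured compounds named here, the one measured step that bears on this is a step that the two limits leave unreadable from compound 1 to compound 2 with fluoro in place of methoxy on an aromatic carbon. Both ends of that step are limits, so its size cannot be read.

The expectation for compound 4 therefore rests on the limit of > 50000 nM in this assay, at which 3 of the 3 values shown sit, and no step beyond the scatter is expected in this assay in either direction. The estimated step of a number no higher from compound 2 to compound 4 (the limit leaves the size open) is no more than a nominal one. For compound 4 the expected value is 50000 nM with an estimated range from 20000 nM to 100000 nM and a report of only a limit is the likeliest outcome.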

Compound 4, half-maximal inhibitory concentration: > 50000 nM
Compound 4 gave a limit, no number; the forecaster's own chance of this, stated with the estimate: 85%; the middle value sits exactly at the limit.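

No new step can be read: compound 4 stands at a limit, not a number, in this assay, as do compound 1 and compound 2, and the steps from those two to compound 4 cannot be sized. The compounds shown leave open how far each lies past the limit, and which change on the shared core would give a measured number: the limit of > 50000 nM in this assay, at which 4 of the 4 values shown sit.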